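This account rests on a few compounds, and the source may have more. Where it says the series, first, only, none or still open, it means among the compounds named here.

Three compounds have been measured in a functional assay on A549 cells (Homo sapiens) for inhibition, read by MTT assay, with a stated time of 72 h; on this read-out higher numbers stand for weaker inhibition and lower numbers for stronger inhibition:
Compound 1 `O=C1C[C@H]2O[C@H]([C@H](O)c3ccccc3)[C@H](O)[C@H]2O1` gives 35200 nM.
Compound 2 `CO[C@@H](c1ccccc1)[C@H]1O[C@@H]2CC(=O)O[C@@H]2[C@H]1O` gives 5310 nM.
Compound 3 `CO[C@H](c1ccccc1)[C@H]1O[C@@H]2CC(=O)O[C@@H]2[C@H]1O` gives 2640 nM.

Compound 3 shows the lowest of the three numbers, though compound 2 sits close, a 2.0-fold lower number from compound 2 to compound 3 (0.30 log units; within the scatter), and the two differ only in configuration as drawn (the fact that compounds 2 and 3 differ only in the configuration as drawn). Compound 1 lies well apart, a 13-fold lower number from compound 1 to compound 3 (1.12 log units; beyond the scatter). Compound 4 `CO[C@@H]1[C@H]2OC(=O)C[C@H]2O[C@@H]1[C@H](OC)c1ccccc1` has not yet been measured. It differs from compound 3 in one place: methyl in place of hydrogen on an oxygen on a saturated carbon. One measured step is of the same kind, a 13-fold lower number from compound 1 to compound 3 (1.12 log units; beyond the scatter), in which a hydroxy became a methoxy at a different oxygen and the number fell a great deal. A fall in this assay is therefore expected for compound 4 as well, estimated at a 1.8-fold lower number from compound 3 to compound 4 (0.25 log units; within the scatter), smaller than the earlier step, which concerned a different oxygen. Compound 4 is expected to give 1500 nM, with a range from 500 nM to 5000 nM.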

Compound 4, half-maximal inhibitory concentration: 26300 nM
Estimate against measurement, compound 4: 18-fold (1.24 log units) below, and the stated range ends below it.
By their numbers in this assay, from the lowest: compounds 3 and 2 (each within the scatter of the next); then compounds 4 and 1 (each within the scatter of the next).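

Hydroxy to methoxy at this oxygen gives a 10-fold higher number from compound 3 to compound 4 (1.00 log units; beyond the scatter) and so runs against a 13-fold lower number from compound 1 to compound 3 (1.12 log units; beyond the scatter) at the other oxygen, which shows that the same change does not act alike at both places. At this position, the free hydroxy of compound 3 goes with the lower number. Nothing measured here explains why the two oxygens differ.

As far as these compounds go, what stays open is how other groups behave at this oxygen: an ethoxy, an acetate ester or an amine in place of the hydroxy would show whether the rise is particular to methoxy.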